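The source may hold more compounds than are shown below. What is called first, only, known or untested is meant among the compounds shown, and "the series" means these compounds.

Working notes on the series. In an assay on isolated protein for inhibition of Thromboxane-A synthase (Rattus norvegicus) (a lower number here means a stronger inhibitor, a higher number a weaker inhibitor), compound 3 `O=C(NCCCCCn1ccnc1)c1ccc(Cl)s1` gives 200 nM. Compound 2 `O=C(NCCCCCCn1ccnc1)c1ccc(Cl)s1` gives 200 nM. Compound 1 `O=C(NCCCCn1ccnc1)c1cc2ccccc2[nH]1` gives 40 nM. Compound 3 thus stands level with compound 2 at the digits shown, the two together the highest numbers of the three, while compound 1 sits at a clearly lower number, beyond the scatter.

Compound 4 `O=C(NCCCCn1ccnc1)c1ccc(Cl)s1` is the next member. From compound 3 to compound 4 the change is 1H-imidazol-1-yl in place of (1H-imidazol-1-yl)methyl on a saturated chain carbon, four bonds along the chain from an amide-type nitrogen. Within the data shown here, one measured step bears on it directly: the same kind of shortening of the chain, one bond further from the amide nitrogen, is seen in the step of no change at the digits printed from compound 2 to compound 3 (within the scatter), which was flat. Among the measured compounds shown here, compound 1 shares the chain length of compound 4 but carries a different core, so its value gives no step to read. On the shared core of compounds 2 and 3 the chain length has so far made no difference, so the step in this assay is expected to be none beyond the scatter, no change at the digits printed from compound 3 to compound 4 (within the scatter). Compound 4 is therefore estimated at 200 nM, with a range from 80 nM to 500 nM.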

Compound 4, half-maximal inhibitory concentration: 200 nM
Estimate against measurement, compound 4: no gap at the digits printed; measured number inside the range.
By their numbers in this assay, from the lowest: compound 1; then compounds 2, 3 and 4 (each within the scatter of the next).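

In this assay the shortening of the chain stays flat a second time, no change at the digits printed from compound 3 to compound 4 (within the scatter), so on the shared core 1H-imidazol-1-yl in place of (1H-imidazol-1-yl)methyl has now been read at two places along the chain without a step beyond the scatter. Compounds 2, 3 and 4 stand each within the scatter of the next, which a single earlier step could not show. No measurement at hand accounts for this flat stretch.

With the chain of compound 4 on a different core, compound 1 gives 40 nM, which leaves open whether chain length matters on that core. From the compounds shown here alone, a propyl or heptyl chain on the shared core also remains open, so the limits of the flat stretch are unknown.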